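Thiourea series: trifluoromethoxy replaces chloro in compound 3

This account rests on a few compounds, and the source may have more. Where it says the series, first, only, none or still open, it means among the compounds named here.

Measured so far:
compound 1 `CNC(=O)c1cc(Oc2cccc(NC(=S)Nc3ccc(Cl)cc3)c2)ccn1` — 24100 nM
compound 2 `O=C(NCc1ccccc1)c1cc(Oc2cccc(NC(=S)Nc3ccc(Cl)cc3)c2)ccn1` — 15800 nM

In a functional assay on PC-3 cells (Homo sapiens) for cytotoxicity, read by MTT assay, with a stated time of 48 h (on this read-out higher numbers stand for weaker inhibition and lower numbers for stronger inhibition), compound 2 gives 15800 nM, separated from compound 1 only by a 1.5-fold lower number from compound 1 to compound 2 (0.18 log units; within the scatter), so the two numbers lie within the scatter of each other. Compound 3 `O=C(NCc1ccccc1)c1cc(Oc2cccc(NC(=S)Nc3ccc(OC(F)(F)F)cc3)c2)ccn1` differs from compound 2 by trifluoromethoxy in place of chloro on an aromatic carbon. Within the data shown here, no measured step touches this place; the single step of a 1.5-fold lower number from compound 1 to compound 2 (0.18 log units; within the scatter) concerns another part of the shared core and gives no guide. Without a comparable step, no change beyond the scatter is expected in this assay, so the estimated step is a 1.1-fold lower number from compound 2 to compound 3 (0.02 log units; within the scatter). Compound 3 is expected at 15000 nM, with a range of 5000 nM to 45000 nM.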

Compound 3, half-maximal inhibitory concentration: 6800 nM
Estimate against measurement, compound 3: 2.2-fold (0.34 log units) above; the range from low to high includes it.
By their numbers in this assay, from the lowest: compound 3; then compounds 2 and 1 (each within the scatter of the next).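

In this assay, among these compounds, the change from 4-chlorophenyl to 4-(trifluoromethoxy)phenyl gives a 2.3-fold lower number from compound 2 to compound 3 (0.37 log units; beyond the scatter) and is the only step so far beyond the scatter. The number thus responds to the group on this aromatic carbon, whereas the earlier step of a 1.5-fold lower number from compound 1 to compound 2 (0.18 log units; within the scatter) in another part of the shared core stayed within the scatter. Nothing measured here bears on the reason for this step. Still open, as far as these compounds go, is how a methoxy group, an amine or plain hydrogen at this place would compare, and whether the same exchange holds on the amide of compound 1.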